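Benzyl in place of isobutyl on a shared core

The source may report more compounds than this note shows. Statements on the series, on what has been measured and on what is new or still open speak of the compounds shown alone.

Three measured compounds share one core and differ only in the chain on the nitrogen. In a physicochemical assay for acid dissociation, compound 1 `CCCCCN(C1=NCCN1)c1c(Br)cccc1Br` gives 11, compound 2 `CC(C)CN(C1=NCCN1)c1c(Br)cccc1Br` gives 11 and compound 3 `Brc1cccc(Br)c1N(CC1CCC1)C1=NCCN1` gives 10.9. Compound 2 stands level with compound 1 at the digits shown, and compound 3 sits apart from both only within the scatter: the steps of no change at the digits printed from compound 1 to compound 2 (within the scatter), a number 0.10 log units lower from compound 1 to compound 3 (within the scatter) and a number 0.10 log units lower from compound 2 to compound 3 (within the scatter) are all within it. Compound 4 `Brc1cccc(Br)c1N(Cc1ccccc1)C1=NCCN1` is not yet measured; it differs from compound 2 by phenyl in place of isopropyl on a saturated chain carbon bound to a nitrogen on an aromatic ring. Every measured exchange at that chain carbon left this assay unmoved, so no step beyond the scatter is expected for compound 4. Compound 4 is therefore estimated at 10.9, between 10.5 and 11.3, an expected step of a number 0.10 log units lower from compound 2 to compound 4 (within the scatter).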

Compound 4, acid dissociation constant: 10.4
The estimate for compound 4 lay 0.50 log units above the measured number, and the stated range ends above it.
By their numbers in this assay, from the lowest: compound 4; then compounds 3, 1 and 2 (each within the scatter of the next).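

Phenyl is the first group on this saturated chain carbon bound to a nitrogen on an aromatic ring to move the number in this assay beyond the scatter (a number 0.60 log units lower from compound 2 to compound 4 (beyond the scatter)) and (a number 0.50 log units lower from compound 3 to compound 4 (beyond the scatter)) and (a number 0.60 log units lower from compound 1 to compound 4 (beyond the scatter)). Among these compounds, the one aromatic ring separates compound 4 from the butyl, isopropyl and cyclobutyl compounds, which remain within the scatter of one another. Nothing available accounts for this step. Going by these compounds, whether pyridyl or a phenethyl chain would give a similar step remains open, as does whether this step holds on another core.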